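From 2-aminophenyl to 4-fluorophenyl on an amide-type nitrogen

A few compounds are considered here, and "the series" means these few. Any claim that something is new, unique, unknown or untested is made for them only; others in the source may bear on it.

In an ADME assay on HepG2 cells (Homo sapiens) for cytotoxicity, with a stated time of 72 h (a higher number here means that more compound is needed for the effect, a lower number that less compound is needed), compound 1 (`CC(=O)c1ccc(NC(=O)Nc2cc(C)nc3ccccc23)cc1`) gives 19000 nM as a measured number. Compound 2 (`Cc1cc(NC(=O)Nc2ccccc2N)c2ccccc2n1`) gives > 25000 nM as a limit of the assay and not a number. Compound 2 is therefore placed only by the limit of > 25000 nM in this assay, at which 1 of the 2 values shown sits, and has no exact value.

Compound 3 (`Cc1cc(NC(=O)Nc2ccc(F)cc2)c2ccccc2n1`) has not yet been measured. It carries 4-fluorophenyl in place of 2-aminophenyl on an amide-type nitrogen. Among the compounds with values here, no measured pair shows what such a change does in this assay so the expectation rests on compound 1 at 19000 nM as the only number available. A small move toward less compound needed is expected, perhaps none beyond the scatter, and the estimated step is an at least 1.3-fold lower number from compound 2 to compound 3 (0.14 log units; that floor lies within the scatter) on this reasoning. For compound 3 the estimated value is 18000 nM with an expected range from 7000 nM to 35000 nM in this assay.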

Compound 3, half-maximal effective concentration: > 25000 nM
Compound 3: a limit, no number; the forecaster's own chance of this, stated with the estimate: 40%; middle value at least 1.3-fold (0.14 log units) from the limit.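

In this assay compound 3 gives > 25000 nM, which is a limit of the assay and not a number. Within the data shown here, the change from 2-aminophenyl to 4-fluorophenyl on the amide-type nitrogen thus leaves compound 3 at the same limit as compound 2, so the step between them cannot be read: the limit of > 25000 nM in this assay, at which 2 of the 3 values shown sit. Fluoro in place of acetyl on an aromatic carbon gives the only readable step, an at least 1.3-fold higher number from compound 1 to compound 3 (0.11 log units; that floor lies within the scatter), and it shows a direction for the first time, though its floor does not clear the scatter.

Where compound 2 and compound 3 actually stand, and whether they differ at all, remains open. Also open, as far as these compounds go, is whether a carboxylic acid or a methoxy group in place of fluoro on that aromatic carbon would give a number rather than a limit in this assay.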